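The compounds below may be only part of what the source reports. "The series", "measured", "known", "first", "only" and "open" are said of these compounds alone.

Series notes. Compound 1 `ClCc1ccc(Cn2cnc3c(Cl)ncnc32)cc1` and compound 2 `ClCc1ccccc1Cn1cnc2c(Cl)nc(Cl)nc21` share a fused core carrying a benzyl group with a chloromethyl arm. In a functional assay on 786-0 cells (Homo sapiens) for cytotoxicity, read by sulforhodamine B assay, with a stated time of 48 h (on this read-out higher numbers stand for weaker inhibition of growth and lower numbers for stronger inhibition of growth), compound 1 gives 1020 nM. In this assay, for the measured compounds named here, compound 2 gives 1860 nM, the higher of the two numbers so far, though the gap to compound 1 lies within the scatter of the read-out. Compound 3 `ClCc1ccccc1Cn1cnc2c(Cl)ncnc21` is the next entry. Relative to compound 2 it carries hydrogen in place of chloro on an aromatic carbon, in words: hydrogen in place of chloro on an aromatic carbon; the remaining core then matches that of compound 1. Going by the values given here, no measured step of this kind exists. The expected step of a 1.4-fold lower number from compound 2 to compound 3 (0.16 log units; within the scatter) is small, toward a lower number if anything, and not clearly beyond the scatter, because compound 1 with the same core gives 1020 nM. For compound 3 the estimated concentration for half-maximal growth inhibition is 1300 nM, with a range from 500 nM to 3500 nM.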

Compound 3, concentration for 50% growth inhibition: 17800 nM
Compound 3: the middle estimate sits 14-fold (1.14 log units) below what was measured; the whole stated range lies below it.
By their numbers in this assay, from the lowest: compounds 1 and 2 (each within the scatter of the next); then compound 3.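

In this assay, the series now has its first measured step at the aromatic carbon between two ring nitrogen atoms: hydrogen in place of chloro gives a 9.6-fold higher number from compound 2 to compound 3 (0.98 log units; beyond the scatter), so with the chloromethyl arm placed as in compound 2, the number depends strongly on this chloro. Compound 1 also has hydrogen at this carbon and gives 1020 nM, whereas compound 3 gives 17800 nM, so the loss of the chloro does not by itself fix the number; the placement of the chloromethyl arm on the benzyl ring differs between these two compounds. Nothing measured here accounts for the size of this step.

The compounds shown leave open whether an amine or a methoxy group on this carbon would give a number nearer that of compound 2 or that of compound 3. They also leave open whether chloro at this carbon would shift the number in the same way with the arm placed as in compound 1.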